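The source may hold more compounds than are shown below. What is called first, only, known or untested is meant among the compounds shown, and "the series" means these compounds.

Compound 1 `CCCC(=O)OC1CCN(c2ccc(-c3ccccc3Cl)nn2)CC1`: 39 mg/kg
Compound 2 `CNC(=O)OC1CCN(c2ccc(-c3ccccc3Cl)nn2)CC1`: 13 mg/kg
Compound 3 `C/N=C(\S)OC1CCN(c2ccc(-c3ccccc3Cl)nn2)CC1`: not yet measured

In a functional assay on the whole organism with Mus musculus as the target (a lower number here means that less compound is needed, a higher number that more compound is needed for the effect), compound 2 gives the lower of the two numbers, at 13 mg/kg, so less of it is needed than of compound 1. Compound 3 differs from compound 2 in one place, on an oxygen on a saturated carbon, where methylcarbamoyl leaves: a group of 4 heavy atoms (2 carbon, 1 nitrogen, 1 sulfur; no ring) in place of a group of 4 heavy atoms (2 carbon, 1 nitrogen, 1 oxygen; no ring), on an oxygen on a saturated carbon. The entering group holds sulfur where the leaving group holds oxygen.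

For the measured compounds named here, only one measured step bears on this change. That step, a 3.0-fold lower number from compound 1 to compound 2 (0.48 log units; beyond the scatter), is modest and alters the same place, replacing propyl with methylamino on a carbonyl carbon. It does not show what a swap of oxygen for sulfur does, so the evidence here is thin. Going by the values given here, with no direct precedent, no clear shift in this assay is expected, and the expected change is a 1.2-fold higher number from compound 2 to compound 3 (0.09 log units; within the scatter). For compound 3 the estimated dose is 16 mg/kg, with an expected range from 6 mg/kg to 42 mg/kg.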

Compound 3, dose for half-maximal effect: 20 mg/kg
Compound 3: middle estimate off by 1.3-fold (0.10 log units), on the low side; the range from low to high includes it.
By their numbers in this assay, from the lowest: compounds 2, 3 and 1 (each within the scatter of the next, the first and the last beyond it).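

In this assay, the swap at this place, on an oxygen on a saturated carbon, gives a 1.5-fold higher number from compound 2 to compound 3 (0.19 log units; within the scatter), so a group holding sulfur in place of the oxygen of methylcarbamoyl cannot be told apart from methylcarbamoyl in this measurement. The comparison with the ester-bearing compound gives a 2.0-fold lower number from compound 1 to compound 3 (0.29 log units; within the scatter), which means the new compound cannot be separated from that one either, even though the earlier pair was separated by a 3.0-fold lower number from compound 1 to compound 2 (0.48 log units; beyond the scatter) and so the three compounds do not fall into a clean order. Nothing available here offers a measured reason for how this swap behaves in the whole animal.

The compounds shown leave open how far this place tolerates larger changes, for example a longer chain such as ethyl or propyl in place of the methyl on the nitrogen, or a phenyl ring there. They also leave open what this assay would show with a simple hydroxyl group at this carbon, with no carbonyl-type group attached, or with an amine in place of the oxygen.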